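Adding a methyl to the methylsulfonyl side chain

The compounds below may be only part of what the source reports. "The series", "measured", "known", "first", "only" and "open" are said of these compounds alone.

Of the compounds shown here, two have so far been measured in an ADME assay on N2a cells (Mus musculus) for cytotoxicity; a lower number here means that less compound is tolerated, a higher number that more compound is tolerated. Compound 1 `CC1=CC(C)(C)Nc2c(C(=O)N[C@@H](C)/C=C/S(C)(=O)=O)cccc21` gives > 25000 nM, which is a limit of the assay and not a number. Compound 2 `C[C@@H]1CC(C)(C)Nc2c(C(=O)NC/C=C/S(C)(=O)=O)cccc21` gives > 25000 nM, which is likewise a limit. Within the data shown here, compound 2 therefore has no exact value of its own, and no step between measured compounds can be read.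

Compound 3 `C[C@@H]1CC(C)(C)Nc2c(C(=O)N[C@@H](C)/C=C/S(C)(=O)=O)cccc21` arises from compound 2 through one change: methyl in place of hydrogen on a saturated chain carbon bound to an amide-type nitrogen and a double-bonded chain carbon. A methyl takes the place of hydrogen on a saturated chain carbon bound to an amide-type nitrogen and a double-bonded chain carbon, so that 3-(methylsulfonyl)prop-2-en-1-yl becomes 1-methyl-3-(methylsulfonyl)prop-2-en-1-yl.

No shift beyond the usual scatter is expected in this assay, in either direction. This expectation rests on compound 1 and compound 2, which both stand at the limit of > 25000 nM in this assay, at which 2 of the 2 values shown sit. The estimated a number no higher from compound 2 to compound 3 (the limit leaves the size open) is expected to stay within the scatter. Compound 3 is expected at an estimated 25000 nM, in a range from 12000 nM to 50000 nM. A further limit is the most likely report.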

Compound 3, half-maximal cytotoxic concentration: > 25000 nM
Compound 3: a limit, no number (the forecaster's own chance of this, stated with the estimate: 85%); the middle value lies on the limit itself.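

In this assay compound 3 gives > 25000 nM, which is a limit of the assay and not a number. Compound 2 also stands at a limit, so no step can be read between compound 2 and compound 3. The compounds shown leave open the exact cytotoxic concentration of each of them, as all share one reading: the limit of > 25000 nM in this assay, at which 3 of the 3 values shown sit.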